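The compounds below may be only part of what the source reports. "The series", "measured", "known", "first", "only" and "open" are said of these compounds alone.

Measured so far:
compound 1, `CCCCCC(=O)Nc1cc2nc(C3CCCCC3)[nH]c2cc1N(CC)CC`: "not determined" (no result reported)
compound 2, `O=C(CCc1ccccc1)Nc1cc2nc(C3CCCCC3)[nH]c2cc1N1CCCC1`: > 100 ug/mL

In an ADME assay on Vero cells (Chlorocebus sabaeus) for cytotoxicity, read by resazurin assay, with a stated time of 3 days (on this read-out lower numbers stand for stronger inhibition and higher numbers for weaker inhibition), compound 1 gives "not determined" (no result reported). In this assay compound 2 gives > 100 ug/mL, which is a limit of the assay rather than a number. For the measured compounds named here, compound 2 therefore stands at the limit of > 100 ug/mL in this assay, at which 1 of the 2 values shown sits; the only other entry carries no number, so no measured step exists for comparison. Compound 3, `O=C(Nc1cc2nc(C3CCCCC3)[nH]c2cc1N1CCCC1)OCC(F)(F)F`, shares the core of compound 2 and differs in one place: 2,2,2-trifluoroethoxy in place of phenethyl on a carbonyl carbon. Without a measured step of this kind to lean on, the expectation for compound 3 rests on compound 2 alone, and the expected step is none beyond the usual scatter, a number no higher from compound 2 to compound 3 (the limit leaves the size open). In this assay compound 3 is accordingly estimated at 100 ug/mL, within a range from 50 ug/mL to 200 ug/mL, with a fair chance that only a limit is reported again.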

Compound 3, half-maximal inhibitory concentration: > 100 ug/mL
Compound 3 gave a limit, no number; the forecaster's own chance of this, stated with the estimate: 80%; the middle value sits exactly at the limit.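

In this assay, compound 2 and compound 3 each give only a limit, not a number, so no step can be read between them: the limit of > 100 ug/mL in this assay, at which 2 of the 3 values shown sit. Still open, going by these compounds, is how far past that limit each compound lies, and whether 2,2,2-trifluoroethoxy in place of phenethyl changes the value at all.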